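A few compounds are considered here, and "the series" means these few. Any claim that something is new, unique, unknown or untested is made for them only; others in the source may bear on it.

In an in vitro ADME assay on microsomes from liver (Homo sapiens) for metabolic stability (on this read-out lower numbers stand for slow clearance and higher numbers for fast clearance), compound 1 (`COc1cccc(S(=O)(=O)c2c(C)n(CC(=O)O)c3ccc(C)cc23)c1`) gives 3 mL.min-1.g-1, while compound 2 (`Cc1c(Sc2ccc(Cl)cc2)c2cc(-c3ccccc3)ccc2n1CC(=O)O`) gives 16 mL.min-1.g-1, the higher of the two numbers and a gap beyond the usual scatter. Compound 3 (`Cc1c(Sc2ccc(Cl)cc2)c2cc(F)ccc2n1CC(=O)O`) differs from compound 2 in one place: fluoro in place of phenyl on an aromatic carbon, with fluoro in place of phenyl on an aromatic carbon. For the measured compounds named here, no measured pair of compounds shows what this swap does, which leaves the expectation on thin ground. A moderate move toward slower clearance is expected, estimated as a 2.3-fold lower number from compound 2 to compound 3 (0.36 log units; beyond the scatter). For compound 3 the estimated value is 7 mL.min-1.g-1, with an expected range of 3 mL.min-1.g-1 to 16 mL.min-1.g-1.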

Compound 3, intrinsic clearance in microsomes in the Homo sapiens assay: < 3 mL.min-1.g-1
Compound 3 was reported as a limit (the forecaster's own chance of this, stated with the estimate: 5%); middle value at least 2.3-fold (0.36 log units) away from the limit.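

In the Homo sapiens assay, replacing the phenyl with a fluoro group gives an at least 5.3-fold lower number from compound 2 to compound 3 (0.72 log units; beyond the scatter), the first direct sign that this position matters for clearance. In the Homo sapiens assay compound 3 gives < 3 mL.min-1.g-1, which is a limit of the assay and not a number. In a physicochemical assay for lipophilicity, at pH 7.4 (on this read-out higher numbers stand for higher lipophilicity and lower numbers for lower lipophilicity), compound 2 gives 3.7 while compound 3 gives 1.8 on the same read-out. The slower clearance may be linked to the lower lipophilicity that comes with this swap, though one pair cannot prove the link: the measured distribution coefficient of compound 2, 3.7, and of compound 3, 1.8, a number 1.90 log units lower (beyond the scatter)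

On these data alone, whether the phenyl ring itself or lipophilicity drives the change stays open. An amine or a nitrile at this carbon could help separate the two.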